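A few compounds are considered here, and "the series" means these few. Any claim that something is new, unique, unknown or untested is made for them only; others in the source may bear on it.

Measured compounds and their results: compound 1 `O=[N+]([O-])c1cccc(CNc2cc(Br)cc3[nH]ncc23)c1` gives 91%; compound 2 `O=[N+]([O-])c1cccc(CNc2cc(C(F)(F)F)cc3[nH]ncc23)c1` gives 60%; compound 3 `O=[N+]([O-])c1ccc2[nH]c(CNc3cc(C(F)(F)F)cc4[nH]ncc34)cc2c1` gives 54%.

These numbers come from an assay for inhibition of Tryptophan 2,3-dioxygenase (Homo sapiens), with stated times of 10 min and 60 min, tested at 10 uM; a higher number here means a stronger effect of the compound at the concentration tested, a lower number a weaker effect. Among the three, compound 2 stands second highest: its nearest neighbour is compound 3, whose value lies within the scatter of it, while compound 1 sits well above it, as the step of a number 31 percentage points lower from compound 1 to compound 2 (beyond the scatter) shows.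

The next compound, compound 4 `O=C(O)c1cccc(CNc2cc(C(F)(F)F)cc3[nH]ncc23)c1`, differs from compound 2 in one place: carboxy in place of nitro on an aromatic carbon. Going by the values given here, no measured step covers this change. Among the compounds with values here, the only step on record, from compound 1 to compound 2, alters the group on the shared core, not the group on the six-membered ring, so it says little here. Compounds 2 and 3 together show that reshaping the part carrying the nitro leaves the value almost unchanged, but neither keeps or removes the nitro itself.

Within the data shown here, with no direct precedent, a drop in this assay is expected for compound 4, but with a wide range: the estimate is 35%, between 5% and 70%, meaning an expected step of a number 25 percentage points lower from compound 2 to compound 4 (beyond the scatter).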

Compound 4, a percentage reported as inhibition, at one concentration (the size of the read-out at that concentration, not a potency): 81%
Beside the measured number, compound 4's estimate is 46 percentage points below it, and the stated range ends below it.
By their numbers in this assay, from the lowest: compounds 3 and 2 (each within the scatter of the next); then compounds 4 and 1 (each within the scatter of the next).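

In this assay, the nitro group on this six-membered aromatic ring turns out not to be required for the read-out: replacing it with carboxy gives a number 21 percentage points higher from compound 2 to compound 4 (beyond the scatter) and so moves the value up, not down. Going by these compounds alone, every earlier compound carried the nitro, so they could not show whether this position accepts another group, and this is the first step that changes the group while leaving the rest of the molecule untouched. The two groups have the same count of heavy atoms and differ in that carboxy has a hydrogen-bond donor and nitro has none, but no measurement here links the rise to that difference or to any other cause.

The compounds shown leave open whether other groups in this place, such as an amide, a nitrile or an amine, would behave like carboxy or like nitro. They also leave open whether carboxy in place of nitro would have a similar effect with bromo on the shared core, as in compound 1, or on the larger part carrying the nitro in compound 3.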